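Swapping an Oxane for a Pyrrole on the Amide

The compounds below may be only part of what the source reports. "The series", "measured", "known", "first", "only" and "open" are said of these compounds alone.

Compound 1 `O=C(Nc1ccc(OC(F)(F)F)cc1)NC1CCN(C(=O)C2CCOCC2)CC1` is a urea whose ring-bound amide carries an oxan-4-yl group. In a physicochemical assay for lipophilicity, read by HPLC, with a stated time of 90 min, tested at 100 uM (on this read-out higher numbers stand for higher lipophilicity and lower numbers for lower lipophilicity), compound 1 gives 3.26, the lowest of the three numbers measured. Compound 3 `O=C(Nc1ccc(OC(F)(F)F)c(F)c1)NC1CCN(C(=O)C2CCOCC2)CC1` gives 3.73, and the step of a number 0.47 log units higher from compound 1 to compound 3 (beyond the scatter). For the measured compounds named here, compound 2 `CCC(=O)N1CCC(NC(=O)Nc2ccc(C(F)(F)F)c(F)c2)CC1` gives 3.76; no single-point step links it to compound 1.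

Compound 4 `O=C(Nc1ccc(OC(F)(F)F)cc1)NC1CCN(C(=O)c2cc[nH]c2)CC1` differs from compound 1 in one place: 1H-pyrrol-3-yl in place of oxan-4-yl on a carbonyl carbon. Going by the values given here, none of the measured steps touches this part of the molecule, so there is nothing to read across from them. With no guide, the step is expected to stay within the scatter, a number 0.04 log units higher from compound 1 to compound 4 (within the scatter). Compound 4 is therefore estimated at 3.3, with a range from 2.8 to 3.8.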

Compound 4, partition coefficient: 3.34
Beside the measured number, compound 4's estimate is 0.04 log units below it, within the range that was stated.
By their numbers in this assay, from the lowest: compounds 1 and 4 (each within the scatter of the next); then compounds 3 and 2 (each within the scatter of the next).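

On the carbonyl carbon, 1H-pyrrol-3-yl in place of oxan-4-yl gives a number 0.08 log units higher from compound 1 to compound 4 (within the scatter) in this assay and so leaves the two compounds level. For the compounds shown here, this is the first look at this part of the molecule, since the earlier step, a number 0.47 log units higher from compound 1 to compound 3 (beyond the scatter), concerned fluoro on an aromatic carbon. Here, a five-membered aromatic ring with a hydrogen-bond donor reads like a six-membered non-aromatic ring. From the compounds shown here alone, whether a group carrying an amine or a carboxylic acid at this place would also stay level with compound 1 remains open. Why these two groups read alike also stays open, as no measurement here bears on it.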